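From benzyl to 4-fluorobenzyl in compound 1

This account rests on a few compounds, and the source may have more. Where it says the series, first, only, none or still open, it means among the compounds named here.

compound 1 `COc1ccc(NC(=O)c2cc(N(C)Cc3ccccc3)ncn2)cc1` gives 287000 nM
compound 2 `CN(Cc1ccccc1)c1cc(C(=O)Nc2ccccc2)ncn1` gives 314000 nM
compound 3 `CN(Cc1ccc(F)cc1)c1cncc(C(=O)Nc2ccc(F)cc2)n1` gives 282000 nM

These three values come from an ADME assay on Vero cells (Chlorocebus sabaeus) for cytotoxicity, read by MTT assay; a lower number here means a stronger inhibitor, a higher number a weaker inhibitor. They all lie within the usual scatter of one another, so compound 1 stands level with the other two and no order can be drawn among them.

The next compound is compound 4 `COc1ccc(NC(=O)c2cc(N(C)Cc3ccc(F)cc3)ncn2)cc1`, which keeps the core of compound 1 and places fluoro in place of hydrogen on an aromatic carbon, turning benzyl into 4-fluorobenzyl: fluoro in place of hydrogen on an aromatic carbon.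

For the measured compounds named here, only one measured step bears on this, and only indirectly. It is a different change, hydrogen in place of methoxy on an aromatic carbon, and it gave a 1.1-fold higher number from compound 1 to compound 2 (0.04 log units; within the scatter), which is within the scatter. Compound 3 also carries a 4-fluorobenzyl group, but it differs from compound 1 in other ways too, and compound 3 gives 282000 nM, level with compound 1. Going by the values given here, nothing measured so far points to a real shift in this assay, so no step beyond the scatter is expected.

The expected step is a 1.0-fold lower number from compound 1 to compound 4 (0.01 log units; within the scatter). For compound 4 the estimated value is 280000 nM, with an expected range of 170000 nM to 450000 nM.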

Compound 4, half-maximal inhibitory concentration in the Vero assay: 60500 nM
Beside the measured number, compound 4's estimate is 4.6-fold (0.67 log units) above it; the measured number lies below the stated range.
By their numbers in the Vero assay, from the lowest: compound 4; then compounds 3, 1 and 2 (each within the scatter of the next).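

Compounds 1, 2 and 3 gave no step beyond the scatter, but this position on the benzyl group does respond: in the Vero assay, the exchange of a single hydrogen for fluoro gives a 4.7-fold lower number from compound 1 to compound 4 (0.68 log units; beyond the scatter). In a physicochemical assay for solubility, using the shake flask method, measured as kinetic solubility, with a stated time of 2 h, at pH 7.4 (on this read-out higher numbers stand for higher solubility and lower numbers for lower solubility), compound 1 gives < 5000 nM, which is a limit of the assay and not a number. In the physicochemical assay compound 4 gives 62000 nM. The same single change, with the rest of the molecule held fixed, also goes with a higher reading in the physicochemical assay: the measured solubility of compound 1, < 5000 nM, and of compound 4, 62000 nM, an at least 12-fold higher number (1.09 log units; beyond the scatter)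

The compounds shown leave open whether these shifts belong to fluoro itself or would also appear with chloro, methyl or a nitrile in the same place on the benzyl group. On these data alone, it is also open whether the change would act in the same way without the methoxy of compound 1, as in a 4-fluorobenzyl version of compound 2, and compound 3 cannot settle this, as it carries 4-fluorobenzyl but differs from compound 1 in other places too.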